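Taking the bromo group off compound 1

The compounds below may be only part of what the source reports. "The series", "measured", "known", "first", "only" and "open" are said of these compounds alone.

In a functional assay on K-562R cells (Homo sapiens) for cytotoxicity, read by XTT assay, with a stated time of 24 h (on this read-out lower numbers stand for stronger inhibition and higher numbers for weaker inhibition), compound 1 `Cc1ccc(NC(=O)c2ccc(Br)cc2OCCCCn2ccnc2)cc1Nc1nccc(-c2cccnc2)n1` gives 44600 nM. Compound 2 `Cc1ccc(NC(=O)c2ccc([N+](=O)[O-])c(OCCCCn3ccnc3)c2)cc1Nc1nccc(-c2cccnc2)n1` gives 47600 nM, which is within the scatter of compound 1, so the two cannot be told apart on this read-out. Compound 3 `COc1ccc(C(=O)Nc2ccc(C)c(Nc3nccc(-c4cccnc4)n3)c2)cc1OCCCCn1ccnc1` gives 18700 nM, a clearly lower number than either, which leaves compound 1 at the weaker end of the three alongside compound 2.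

Compound 4 `Cc1ccc(NC(=O)c2ccccc2OCCCCn2ccnc2)cc1Nc1nccc(-c2cccnc2)n1` differs from compound 1 in a single place: hydrogen in place of bromo on an aromatic carbon. This puts hydrogen in place of bromo on an aromatic carbon, meta to a 4-(1H-imidazol-1-yl)butoxy group.

Within the data shown here, no measured pair shows this exact swap. The nearest evidence is one step that exchanges one small group for another, a 2.5-fold lower number from compound 2 to compound 3 (0.41 log units; beyond the scatter), with methoxy in place of nitro. That step is modest and involves different groups, so it is only a loose guide, and it gives no direction for losing a bromo group. The expected change in this assay is therefore none beyond the scatter, and the estimated step is a 1.1-fold lower number from compound 1 to compound 4 (0.05 log units; within the scatter). For compound 4 the expected value is 40000 nM, with an estimated range from 17000 nM to 90000 nM.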

Compound 4, half-maximal inhibitory concentration: 83400 nM
For compound 4 the middle estimate is 2.1-fold (0.32 log units) below the measured one; low and high end bracket the measured number.
By their numbers in this assay, from the lowest: compound 3; then compounds 1, 2 and 4 (each within the scatter of the next).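

In this assay, the step for hydrogen in place of bromo is a 1.9-fold higher number from compound 1 to compound 4 (0.27 log units; within the scatter). On this aromatic carbon, meta to a 4-(1H-imidazol-1-yl)butoxy group and para to a large group, the two compounds therefore cannot be told apart: the gap can look wide at first sight, yet it stays inside the normal spread of repeated measurements. Among these compounds, the earlier compounds offered no such reading, as none of them differed from compound 1 in a single place, and the one earlier step, a 2.5-fold lower number from compound 2 to compound 3 (0.41 log units; beyond the scatter), concerned methoxy and nitro rather than bromo, so this is the first direct look at losing the bromo group, and nothing available explains the result.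

What the compounds shown leave open is whether any other group on this same carbon, such as an amine, a carboxylic acid or a longer alkyl chain, would give a step beyond the scatter. One pair also cannot say whether bromo and hydrogen would read alike on the other carbons of this ring.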